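A few compounds are considered here, and "the series" means these few. Any claim that something is new, unique, unknown or untested is made for them only; others in the source may bear on it.

Among the compounds with values here, compound 3 `COc1cc2c(Oc3ccc(NC(=O)c4nn(-c5ccccc5OC(F)(F)F)c(=O)cc4C)cc3F)ccnc2cc1OCCCN1CCC(C)CC1` gives 90 nM in a functional assay on A549 cells (Homo sapiens) for inhibition, read by MTT assay, with a stated time of 72 h (on this read-out higher numbers stand for weaker inhibition and lower numbers for stronger inhibition), the lowest of the three numbers so far; compound 2 `COc1cc2c(Oc3ccc(NC(=O)c4nn(-c5ccccc5C(F)(F)F)c(=O)cc4C)cc3F)ccnc2cc1OCCCN1CCN(C)CC1` gives 170 nM, within the scatter of that figure, while compound 1 `COc1cc2c(Oc3ccc(NC(=O)c4nn(-c5ccccc5)c(=O)cc4C)cc3F)ccnc2cc1OCCCN1CCN(C)CC1` gives 350 nM, beyond it. Compound 4 `COc1cc2c(Oc3ccc(NC(=O)c4nn(-c5ccccc5OC(F)(F)F)c(=O)cc4C)cc3F)ccnc2cc1OCCCN1CCN(C)CC1` differs from compound 3 by 4-methylpiperazin-1-yl in place of 4-methylpiperidin-1-yl on a saturated chain carbon, three bonds along the chain from an oxygen on an aromatic ring. Within the data shown here, the only single-point step measured, a 2.1-fold lower number from compound 1 to compound 2 (0.31 log units; beyond the scatter), concerns a substituent on an aromatic carbon and says nothing about the chain terminus; compounds 2 and 3 differ in two places, so their values show only a combined effect. Among the measured compounds shown here, no measured step therefore bears on this change, and in this assay no step beyond the scatter is expected for compound 4: no change at the digits printed from compound 3 to compound 4 (within the scatter). Compound 4 is estimated at 90 nM, with a range of 45 nM to 180 nM.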

Compound 4, half-maximal inhibitory concentration: 130 nM
Compound 4: the middle estimate sits 1.4-fold (0.16 log units) below what was measured; the measured number falls inside the stated range.
By their numbers in this assay, from the lowest: compounds 3, 4 and 2 (each within the scatter of the next); then compound 1.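

In this assay, within the data shown here, the chain terminus gives the first measured step at this place: 4-methylpiperazin-1-yl in place of 4-methylpiperidin-1-yl gives a 1.4-fold higher number from compound 3 to compound 4 (0.16 log units; within the scatter). On the aromatic carbon, trifluoromethoxy in place of trifluoromethyl gives a 1.3-fold lower number from compound 2 to compound 4 (0.12 log units; within the scatter), and trifluoromethoxy in place of hydrogen gives a 2.7-fold lower number from compound 1 to compound 4 (0.43 log units; beyond the scatter), so trifluoromethoxy separates from hydrogen but not from trifluoromethyl. No evidence available here accounts for these steps.

Open, on these data alone, is whether a morpholin-4-yl or dimethylamino terminus, or a butyl chain in place of the propyl chain, would keep the number within the scatter of these values.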